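A few compounds are considered here, and "the series" means these few. Any claim that something is new, unique, unknown or untested is made for them only; others in the source may bear on it.

In a functional assay on BXPC-3 cells (Homo sapiens) for inhibition, read by MTT assay, with a stated time of 72 h (a higher number here means a weaker inhibitor, a lower number a stronger inhibitor), compound 1 `Cc1ccc(C(=O)Nc2cccc3cccnc23)cn1` reaches only a limit, > 10000 nM. Compound 2 `CC(C)(C)OC(=O)NCCOc1cc(NC(=O)c2cnccn2)c2ncccc2c1` gives 9170 nM. Among the measured compounds shown here, compound 3 `Cc1cnc(C(=O)Nc2cc(OCCNC(=O)OC(C)(C)C)cc3cccnc23)cn1` gives 3670 nM, the lowest number so far. For the measured compounds named here, the only measured step is a 2.5-fold lower number from compound 2 to compound 3 (0.40 log units; beyond the scatter), with methyl in place of hydrogen on an aromatic carbon.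

Next is compound 4 `Cc1cnc(C(=O)Nc2cc(OCCC3CCNCC3)cc3cccnc23)cn1`, with piperidin-4-yl in place of (tert-butoxycarbonyl)amino on a saturated chain carbon, two bonds along the chain from an oxygen on an aromatic ring. The measured step does not touch this chain, so it serves only as a guide to scale, and the direction in this assay remains weakly supported. A modest move is expected, namely a 1.8-fold lower number from compound 3 to compound 4 (0.26 log units; within the scatter). Compound 4 is estimated at 2000 nM, with an expected range of 400 nM to 9000 nM.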

Compound 4, half-maximal inhibitory concentration: 8330 nM
For compound 4 the middle estimate is 4.2-fold (0.62 log units) below the measured one; the range from low to high includes it.
By their numbers in this assay, from the lowest: compound 3; then compounds 4 and 2 (each within the scatter of the next). At a limit, above all of these: compound 1.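

At the saturated chain carbon, two bonds along the chain from an oxygen on an aromatic ring, the exchange of (tert-butoxycarbonyl)amino for piperidin-4-yl gives a 2.3-fold higher number from compound 3 to compound 4 (0.36 log units; beyond the scatter) in this assay. This position therefore responds to the group it carries, and this change does not improve on compound 3. Nothing measured here bears on the cause of the step.

On these data alone, whether the shift follows the ring or its nitrogen remains open. A free primary amine on the same chain, or piperidin-4-yl on a longer chain, would help to separate these.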